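The source may hold more compounds than are shown below. What is called first, only, known or untested is meant among the compounds shown, and "the series" means these compounds.

In a physicochemical assay for solubility (a higher number here means a more soluble compound, a lower number a less soluble compound), compound 1 `O=C(c1ccc(Cl)cc1)N1CCC(NS(=O)(=O)c2cc(S(=O)(=O)c3ccccc3)ccc2C(F)(F)F)CC1` gives 3100 nM, compound 2 `O=C(c1ccc(C(F)(F)F)cc1)N1CCC(NS(=O)(=O)c2cc(S(=O)(=O)c3ccccc3)ccc2C(F)(F)F)CC1` gives 6300 nM and compound 3 `CN(C)c1ccc(C(=O)N2CCC(NS(=O)(=O)c3cc(S(=O)(=O)c4ccccc4)ccc3C(F)(F)F)CC2)cn1` gives 12500 nM. Compound 3 thus stands clear of only one of the others: a 4.0-fold higher number from compound 1 to compound 3 (0.61 log units; beyond the scatter) lies beyond the scatter, while a 2.0-fold higher number from compound 2 to compound 3 (0.30 log units; within the scatter) lies within it. Compound 4 `CC(C)(C)OC(=O)N1CC[C@@H](C(=O)N2CCC(NS(=O)(=O)c3cc(S(=O)(=O)c4ccccc4)ccc3C(F)(F)F)CC2)C1` carries 1-(tert-butoxycarbonyl)pyrrolidin-3-yl in place of 6-(dimethylamino)pyridin-3-yl on a carbonyl carbon. Those same two steps, both changes at this carbonyl carbon, were small, so no step beyond the scatter is expected in this assay, with a slight lean towards a lower number. The estimate is a 1.4-fold lower number from compound 3 to compound 4 (0.14 log units; within the scatter). Compound 4 is expected at 9000 nM, within an estimated range of 3000 nM to 25000 nM.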

Compound 4, solubility: 12500 nM
Estimate against measurement, compound 4: 1.4-fold (0.14 log units) below; low and high end bracket the measured number.
By their numbers in this assay, from the lowest: compound 1; then compounds 2, 3 and 4 (each within the scatter of the next).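

In this assay, a non-aromatic ring on this carbonyl carbon does as well as an aromatic one: the 1-(tert-butoxycarbonyl)pyrrolidin-3-yl group gives no change at the digits printed from compound 3 to compound 4 (within the scatter) for this swap. Among the compounds shown here, the same group gives a 2.0-fold higher number from compound 2 to compound 4 (0.30 log units; within the scatter) and also a 4.0-fold higher number from compound 1 to compound 4 (0.61 log units; beyond the scatter) so, of the earlier compounds, only compound 1 stands clearly apart from compound 4.

A free amine in place of the tert-butoxycarbonyl group, or a carboxylic acid on the pyrrolidine ring, remains an open test at this position. Nothing available explains why these different rings give such similar numbers.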